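The compounds below may be only part of what the source reports. "The series", "measured", "known", "first", "only" and "open" are said of these compounds alone.

So far three compounds have numbers in an ADME assay on microsomes from liver (Homo sapiens) for metabolic stability, with a stated time of 1 h; a higher number here means that more of the compound is left, a lower number that less of the compound is left. Compound 1 `Fc1ccc(Nc2ccc3c(C4CCNCC4)c[nH]c3c2)cc1F` gives 89%, the second highest of the three. Compound 3 `N#Cc1c[nH]c2nc(Nc3ccc4c(C5CCNCC5)c[nH]c4c3)ccc12` sits higher at 100%, and compound 2 `Cn1cc(C2CCNCC2)c2ccc(Nc3ccc(F)c(F)c3)cc21` sits lower at 77%.

Compound 4 `CN1CCC(c2c[nH]c3cc(Nc4ccc(F)c(F)c4)ccc23)CC1` has not been measured yet. It differs from compound 1 by one small edit: methyl in place of hydrogen on an amine nitrogen in a ring. In words, this is methyl in place of hydrogen on an amine nitrogen in a ring.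

Among the compounds with values here, only one measured step comes close to this edit. It puts methyl in place of hydrogen on an aromatic nitrogen, and it shows a number 12 percentage points lower from compound 1 to compound 2 (beyond the scatter). That is a different kind of nitrogen, and a single step is thin evidence, so it serves as a rough guide only. Within the data shown here, compound 3 offers no comparable step.

With that guide, a modest drop of similar size is expected, and the range has to stay wide. The step expected in this assay is a number 11 percentage points lower from compound 1 to compound 4 (beyond the scatter). For compound 4 the estimated value is 78%, with an expected range from 60% to 93%.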

Compound 4, percent of the compound remaining: 91%
Estimate against measurement, compound 4: 13 percentage points below; the measured number falls inside the stated range.
By their numbers in this assay, from the lowest: compound 2; then compounds 1, 4 and 3 (each within the scatter of the next, the first and the last beyond it).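

Putting methyl in place of hydrogen on the amine nitrogen in the six-membered non-aromatic ring gives a number 2 percentage points higher from compound 1 to compound 4 (within the scatter) in this assay and so makes no clear difference at this position. The earlier step on the aromatic nitrogen, a number 12 percentage points lower from compound 1 to compound 2 (beyond the scatter) and thus beyond the scatter, shows that the same methyl does not read the same on the two nitrogens of compound 1. No measurement here explains that contrast.

Going by these compounds, whether this ring nitrogen would also accept something larger than methyl, such as an ethyl group, a longer chain or a chain ending in a carboxylic acid, stays open. On these data alone, it is also open whether the methyl would read the same on the core of compound 3, which carries a nitrile.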